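This account rests on a few compounds, and the source may have more. Where it says the series, first, only, none or still open, it means among the compounds named here.

Compound 2 `CCCCN(c1nc2c(NS(C)(=O)=O)cccc2o1)[C@H](C)c1ccc(-c2ccccc2-c2nnn[nH]2)cc1` gives 4.7 h in an ADME assay on the whole organism (Macaca fascicularis) for metabolic stability, read by LC-MS, using cassette dosing, at a dose of 1 mg/kg by the oral route (a lower number here means that the compound disappears faster, a higher number that the compound lasts longer), and compound 1 `CCCCN(c1nc2c(C(=O)O)cccc2o1)[C@H](C)c1ccc(-c2ccccc2-c2nnn[nH]2)cc1` gives 3.7 h; the gap between these two numbers lies within the scatter, so neither stands apart. Compound 3 `CCCCN(c1nc2c(C(=O)NC)cccc2o1)[C@H](C)c1ccc(-c2ccccc2-c2nnn[nH]2)cc1` differs from compound 2 by methylcarbamoyl in place of methanesulfonamido on an aromatic carbon. Among the measured compounds shown here, the only measured step that bears on this change is a 1.3-fold higher number from compound 1 to compound 2 (0.10 log units; within the scatter), which swapped the group on the same aromatic carbon without moving the half-life beyond the scatter. A further swap there is therefore expected to produce no step beyond the scatter, and the estimated step of a 1.1-fold lower number from compound 2 to compound 3 (0.05 log units; within the scatter) is small. Compound 3 is expected to give 4.2 h, within 2 h to 9 h.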

Compound 3, half-life: 1.3 h
Compound 3: middle estimate off by 3.2-fold (0.51 log units), on the high side; measured number below the stated range.
By their numbers in this assay, from the lowest: compound 3; then compounds 1 and 2 (each within the scatter of the next).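

On this aromatic carbon the group does matter in this assay: methylcarbamoyl in place of methanesulfonamido gives a clear drop (a 3.6-fold lower number from compound 2 to compound 3 (0.56 log units; beyond the scatter)), and methylamino in place of hydroxy on the carbonyl carbon gives another (a 2.8-fold lower number from compound 1 to compound 3 (0.45 log units; beyond the scatter)). The earlier swap, which stayed within the scatter, therefore does not hold for every group at this position. Nothing available explains the shorter half-life of compound 3.

As far as these compounds go, whether the methyl on the amide nitrogen matters remains open. A plain carbamoyl or a dimethylcarbamoyl group at this position could show whether the half-life follows that methyl or the amide itself.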